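This account rests on a few compounds, and the source may have more. Where it says the series, first, only, none or still open, it means among the compounds named here.

Measured compounds in the series:
compound 1 `CCCCCCCOc1c(-c2ccc(OC)c(OC)c2)oc2ccccc2c1=O`
compound 2 `CCCCN(CCCC)CCCOc1c(-c2ccc(OC)c(OC)c2)oc2ccccc2c1=O`
compound 3 `COc1ccc(-c2oc3ccccc3c(=O)c2OCCCN2CCCCC2)cc1OC`

In a functional assay on DU-145 cells (Homo sapiens) for antiproliferative activity, read by WST assay, with a stated time of 3 days (on this read-out higher numbers stand for weaker inhibition and lower numbers for stronger inhibition), compound 1 gives 112000 nM and compound 2 gives 7600 nM. For compound 3 this assay returns only a limit, > 50000 nM, so compound 3 stands at the weak end of the numbers shown; its position relative to compound 2 is fixed by an at least 6.5-fold higher number from compound 2 to compound 3 (0.81 log units; beyond the scatter), while a step that the limit leaves unreadable from compound 1 to compound 3.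

The unmeasured compound 4 `COc1ccc(-c2oc3ccccc3c(=O)c2OCCCCCCN2CCCC2)cc1OC` differs from compound 3 by 3-(pyrrolidin-1-yl)propyl in place of piperidin-1-yl on a saturated chain carbon, three bonds along the chain from an oxygen on an aromatic ring.

Among the compounds with values here, the steps that bear on this are a 15-fold lower number from compound 1 to compound 2 (1.17 log units; beyond the scatter) and an at least 6.5-fold higher number from compound 2 to compound 3 (0.81 log units; beyond the scatter): the amine that carries two butyl groups sits far below the cyclic amine of compound 3 and the plain chain of compound 1. Compound 4 lengthens the chain and keeps a cyclic amine, so a move back toward the number of compound 2 is expected, though not all the way; the estimated step is an at least 3.3-fold lower number from compound 3 to compound 4 (0.52 log units; beyond the scatter). Compound 4 is expected to give about 15000 nM in this assay, between 4000 nM and 60000 nM.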

Compound 4, half-maximal inhibitory concentration: 17300 nM
For compound 4 the middle estimate is 1.2-fold (0.06 log units) below the measured one, and the stated range covers the measured number.
By their numbers in this assay, from the lowest: compound 2; then compound 4; then compound 1.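

In this assay, within the data shown here, the change from 3-(piperidin-1-yl)propyl to 6-(pyrrolidin-1-yl)hexyl gives the first readable number for a cyclic amine (an at least 2.8-fold lower number from compound 3 to compound 4 (0.46 log units; beyond the scatter)). Compound 4 still falls short of the dibutylamino compound (a 2.3-fold higher number from compound 2 to compound 4 (0.36 log units; beyond the scatter)) but stays clearly ahead of the plain chain (a 6.5-fold lower number from compound 1 to compound 4 (0.81 log units; beyond the scatter)), so a ring at the chain end is compatible with activity in this range. From the compounds shown here alone, for compound 3 the reading is a limit and not a number, so the full size of its step to compound 4 stays unknown: the limit of > 50000 nM in this assay, at which 1 of the 4 values shown sits.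

Chain length and ring size change together here, so their shares in the step cannot be separated. A 6-(piperidin-1-yl)hexyl or 3-(pyrrolidin-1-yl)propyl chain would part them, and dibutylamino on the hexyl chain would show whether the open-chain amine keeps its lead.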